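The source may hold more compounds than are shown below. What is called first, only, known or untested is meant among the compounds shown, and "the series" means these compounds.

Measured so far:
- compound 1, `Cc1ccc(S/C(=C/c2ccc(Cl)c(Cl)c2)C(=O)c2ccc(Br)cc2)cc1`: 50000 nM
- compound 2, `O=C(/C(=C\c1c(O)cc(O)cc1O)SCc1ccc(Cl)c(Cl)c1)c1ccc(Cl)cc1`: 25000 nM
- compound 3, `CC(=O)Oc1ccc(/C=C(\C(=O)c2ccc(Cl)cc2)S(=O)(=O)c2ccc(C)cc2)cc1`: 25000 nM

These three compounds were tested in a functional assay on DU-145 cells (Homo sapiens) for inhibition, read by trypan blue exclusion, with a stated time of 96 h; a higher number here means a weaker inhibitor of growth, a lower number a stronger inhibitor of growth. Compound 1 shows the highest number of the three, though its gaps to compound 2 and to compound 3 both sit within the scatter, so no one of them can be called weaker or stronger than another.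

The step considered here leads from compound 1 to compound 4, `Cc1ccc(S/C(=C/c2c(O)cc(O)cc2O)C(=O)c2ccc(Br)cc2)cc1`. The change is 2,4,6-trihydroxyphenyl in place of 3,4-dichlorophenyl on a double-bonded chain carbon bound to a double-bonded chain carbon. For the measured compounds named here, no directly comparable pair of measured compounds shows what this change does on its own. Compound 2, which also carries the 2,4,6-trihydroxyphenyl group, gives 25000 nM, a number within the scatter of compound 1. A small step toward a lower number, or none beyond the scatter, is therefore expected. Compound 4 is estimated at 25000 nM, between 6000 nM and 70000 nM, which would mean a step of a 2.0-fold lower number from compound 1 to compound 4 (0.30 log units; within the scatter).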

Compound 4, concentration for 50% growth inhibition: > 100000 nM
Compound 4: a limit, no number; the forecaster's own chance of this, stated with the estimate: 20%; at least 4.0-fold (0.60 log units) between middle value and limit.
By their numbers in this assay, from the lowest: compounds 2, 3 and 1 (each within the scatter of the next). At a limit, above all of these: compound 4.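

Setting 2,4,6-trihydroxyphenyl in place of 3,4-dichlorophenyl on this double-bonded chain carbon gives the first direct comparison for this change: an at least 2.0-fold higher number from compound 1 to compound 4 (0.30 log units; that floor lies within the scatter). The change therefore brings no lower number on the core of compound 1, although the floor of this step does not by itself separate the two compounds. Compound 4 gives > 100000 nM, which is a limit and not a number, so the full size of the step stays unknown: the limit of > 100000 nM in this assay, at which 1 of the 4 values shown sits.

As far as these compounds go, how a methoxyphenyl or an aminophenyl group would read at this place remains open. For the compounds shown here, no pair shows this same change on the core of compound 2.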